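This account rests on a few compounds, and the source may have more. Where it says the series, first, only, none or still open, it means among the compounds named here.

In a functional assay on RAW264.7 cells (Mus musculus) for inhibition, read by ELISA, with a stated time of 24 h (a lower number here means that less compound is needed, a higher number that more compound is needed for the effect), compound 2 (`CC/C=C\C[C@H]1C(=O)C=C[C@H]1CC(=O)OC(C)CC`) gives 22000 nM, which lies within the scatter of compound 1 (`CC/C=C\C[C@H]1C(=O)C=C[C@H]1CC(=O)OCCOC`) at 27000 nM. Compound 3 (`CC/C=C\C[C@H]1C(=O)C=C[C@H]1CC(=O)OC1CCCCC1`) differs from compound 2 as follows: cyclohexyl in place of sec-butyl on an oxygen next to a carbonyl group. For the measured compounds named here, the one measured step, a 1.2-fold lower number from compound 1 to compound 2 (0.09 log units; within the scatter), is a change at the same place, on an oxygen next to a carbonyl group. Going by the values given here, with only this small step as a guide, no shift beyond the scatter is expected in this assay. The expected step is a 1.2-fold lower number from compound 2 to compound 3 (0.09 log units; within the scatter). For compound 3 the estimate is 18000 nM, with an expected range of 7000 nM to 40000 nM.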

Compound 3, half-maximal effective concentration: 22000 nM
The estimate for compound 3 lay 1.2-fold (0.09 log units) below the measured number; the measured number falls inside the stated range.
By their numbers in this assay, from the lowest: compounds 2, 3 and 1 (each within the scatter of the next).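

On an oxygen next to a carbonyl group, cyclohexyl adds a six-membered ring where compound 1 and compound 2 carry open chains, and in this assay the number holds (no change at the digits printed from compound 2 to compound 3 (within the scatter); a 1.2-fold lower number from compound 1 to compound 3 (0.09 log units; within the scatter)). This position therefore tolerates a ring as well as the two chains, with all three compounds within the scatter of one another. No evidence at hand accounts for this flat result. Still open, from the compounds shown here alone, is whether an amine, a carboxylic acid or a longer chain at this place would shift the number beyond the scatter.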